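The compounds below may be only part of what the source reports. "The series", "measured", "known", "first", "only" and "open" are said of these compounds alone.

Measured compounds:
Compound 1, `Nc1ccccc1NC(=O)/C=C/c1ccc(CSc2cccc(F)c2)cc1`: 8.56%
Compound 2, `CCc1ccc(SCc2ccc(/C=C/C(=O)Nc3ccccc3N)cc2)cc1`: 13.2%
Compound 3, `CCc1ccc(SCc2ccc(C(=O)Nc3ccccc3N)cc2)cc1`: 25.7%

All three were tested in a functional assay on SMMC-7721 cells (Homo sapiens) for inhibition, read by CCK-8 assay, with a stated time of 72 h, tested at 2 uM; on this read-out higher numbers stand for more inhibition of growth at the one concentration tested and lower numbers for less inhibition of growth. Compound 3 stands highest; compound 2 lies nearer to it and compound 1 furthest, both gaps beyond the scatter. Compounds 2 and 1 share a core and differ only by 3-fluorophenyl in place of 4-ethylphenyl on a sulfur, a change that brought a number 4.6 percentage points lower from compound 2 to compound 1 (within the scatter). Compound 3 carries a different core from compound 2; the difference between the two cores is not broken down here.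

Compound 4, `Nc1ccccc1NC(=O)c1ccc(CSc2cccc(F)c2)cc1`, is compound 3 with 3-fluorophenyl in place of 4-ethylphenyl on a sulfur, the same change as between compounds 2 and 1. Because a number 4.6 percentage points lower from compound 2 to compound 1 (within the scatter) was small, the step from compound 3 to compound 4 is expected to be of similar size, a number 4.7 percentage points lower from compound 3 to compound 4 (within the scatter). Compound 4 is therefore estimated at 21%, expected between 9% and 33%.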

Compound 4, percent growth inhibition at one concentration: 18.6%
Estimate against measurement, compound 4: 2.4 percentage points above; low and high end bracket the measured number.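

In this assay, putting 3-fluorophenyl in place of 4-ethylphenyl on a sulfur gave a number 7.1 percentage points lower from compound 3 to compound 4 (within the scatter). Set beside the earlier step, the change carried from one core to the other without a discernible difference: the same change on two cores in this assay, a number 4.6 percentage points lower (within the scatter) from compound 2 to compound 1 and a number 7.1 percentage points lower (within the scatter) from compound 3 to compound 4, 2.5 percentage points apart, within the scatter of two such steps. Within the data shown here, this shows only that the step stayed small on both cores; with two pairs at one concentration, both steps within the scatter, it shows neither a real effect of the change nor that it would carry to further cores.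

The compounds shown leave open how other groups on the sulfur would fare, such as an amine, a carboxylic acid or a longer chain. They also leave open whether the sulfur itself could be replaced by an oxygen.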